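The source may report more compounds than this note shows. Statements on the series, on what has been measured and on what is new or still open speak of the compounds shown alone.

Measured compounds in an assay on isolated protein for binding affinity to leukotriene B4 receptor 1 (Homo sapiens), tested at 1 uM; on this read-out higher numbers stand for more inhibition at the one concentration tested (going by the name of the read-out) and lower numbers for less inhibition:
compound 1 `CC(=O)c1ccc(OCCCCC#N)cc1O` — 0%
compound 2 `CC(=O)c1cc(C)c(OCCCCC#N)cc1O` — 35%
compound 3 `CC(=O)c1cc(CC2CO2)c(OCCCCC#N)cc1O` — 24%

Compound 1 stands lowest of the three numbers; compound 3 is nearest to it and compound 2 furthest, both gaps beyond the scatter.

The unmeasured compound 4 `CCCc1c(OCCCCC#N)ccc(C(C)=O)c1O` differs from compound 1 by propyl in place of hydrogen on an aromatic carbon.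

Among the compounds with values here, two measured steps bear on this change, each adding a carbon group to the shared core at a spot where compound 1 carries none: a number 35 percentage points higher from compound 1 to compound 2 (beyond the scatter) and a number 24 percentage points higher from compound 1 to compound 3 (beyond the scatter). Both rises are beyond the scatter; the larger came with methyl, the smaller with (oxiran-2-yl)methyl, and a number 11 percentage points lower from compound 2 to compound 3 (beyond the scatter) separates the two. Propyl, like methyl, carries no ring and no hydrogen-bond donor or acceptor, so the methyl case is the closer precedent. Within the data shown here, a rise beyond the scatter is therefore expected in this assay, of modest to large size, though no measured step covers a chain of this length on the core. Compound 4 is estimated at 30%, with a range from 8% to 55%. This estimate means a number 30 percentage points higher from compound 1 to compound 4 (beyond the scatter), expected to fall near the two measured rises.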

Compound 4, a percentage reported as inhibition, at one concentration (the size of the read-out at that concentration, not a potency): 9%
For compound 4 the middle estimate is 21 percentage points above the measured one, and the stated range covers the measured number.
By their numbers in this assay, from the lowest: compounds 1 and 4 (each within the scatter of the next); then compound 3; then compound 2.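

In this assay, propyl on the aromatic carbon ortho to a hydroxy group and ortho to a group of 7 heavy atoms gives a number 9 percentage points higher from compound 1 to compound 4 (within the scatter). A carbon substituent on the ring of compound 1 therefore does not bring a rise beyond the scatter in every case, although the ring carbon taken by propyl differs from the one that carries methyl in compound 2 and (oxiran-2-yl)methyl in compound 3. No available data explain this outcome.

The compounds shown do not separate the effect of the ring carbon from that of the substituent, since propyl appears only at this carbon and methyl only at the other. Still open, going by these compounds, is how methyl or an amine would read at the propyl carbon, and how propyl would read at the methyl carbon of compound 2.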